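The source may hold more compounds than are shown below. What is called first, only, known or untested is meant among the compounds shown, and "the series" means these compounds.

Compound 2, with the structure `Nc1nc2cc(-c3nn(CCCCC(=O)NO)c4ncnc(N)c34)ccc2o1`, is one of two compounds tested in a functional assay on HepG2 cells (Homo sapiens) for inhibition, read by MTT assay, with a stated time of 72 h; on this read-out higher numbers stand for weaker inhibition and lower numbers for stronger inhibition. Compound 2 gives 2100 nM in this assay. Compound 1, with the structure `Nc1nc2cc(-c3nn(CCC(=O)NO)c4ncnc(N)c34)ccc2o1`, is the other. In this assay compound 1 reaches only a limit, > 150000 nM, so no number is known for it. For the measured compounds named here, the one measured step runs from compound 1 to compound 2 and gives an at least 71-fold lower number from compound 1 to compound 2 (1.85 log units; beyond the scatter), resting on (the limit of > 150000 nM in this assay, at which 1 of the 2 values shown sits).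

Compound 3, with the structure `Nc1nc2cc(-c3nn(CCCCCCC(=O)NO)c4ncnc(N)c34)ccc2o1`, has not yet been measured in this assay. It differs from compound 2 in one place: 2-(hydroxycarbamoyl)ethyl in place of hydroxycarbamoyl on a saturated chain carbon, four bonds along the chain from an aromatic nitrogen. This is the same kind of change as from compound 1 to compound 2, lengthening the chain between the shared core and the hydroxamic acid, only set further out along that chain.

Because the earlier step gave an at least 71-fold lower number from compound 1 to compound 2 (1.85 log units; beyond the scatter), a further lengthening is expected to lower the number again, though not as steeply, since the first value was only a limit. For compound 3 the estimated step is a 2.6-fold lower number from compound 2 to compound 3 (0.42 log units; beyond the scatter). Compound 3 is expected to give about 800 nM, within a range from 200 nM to 3000 nM.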

Compound 3, half-maximal inhibitory concentration: 1610 nM
Compound 3: middle estimate off by 2.0-fold (0.30 log units), on the low side; measured number inside the range.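

Set further out along the chain, the same kind of lengthening gives a 1.3-fold lower number from compound 2 to compound 3 (0.12 log units; within the scatter), so in this assay this change cannot be told apart from the ordinary scatter of repeated measurements. The steep drop seen on the first lengthening therefore does not carry on at this position: the two longer chains read alike, and the longest still stands far from the shortest, with an at least 93-fold lower number from compound 1 to compound 3 (1.96 log units; beyond the scatter). The true size of that last step remains unknown, since compound 1 has only a limit and not a number: the limit of > 150000 nM in this assay, at which 1 of the 3 values shown sits.

The compounds shown leave open how the number behaves on a 3-(hydroxycarbamoyl)propyl chain, which would help place where along the chain the drop occurs, and whether a longer chain than that of compound 3 would keep the number level or move it. They also leave open whether the hydroxycarbamoyl group itself matters to the number, a question that a carboxylic acid at the end of the same chain could address.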